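Chlorobenzyl Variants on a Bombesin Receptor Subtype-3 Agonist Series

The compounds below may be only part of what the source reports. "The series", "measured", "known", "first", "only" and "open" are said of these compounds alone.

Measured so far, in an in vitro functional assay on cells for agonist activity at Bombesin receptor subtype-3 (Homo sapiens), read by luminescence and calcium flux; on this read-out higher numbers stand for an effect only at larger amounts of compound and lower numbers for an effect already at smaller amounts:
compound 1 `O=C(O)c1ccccc1-c1ccc(CCc2ncc(C3CCCCC3)[nH]2)cc1`: 375 nM
compound 2 `O=C(O)c1ccccc1-c1ccc(CCc2ncc(Cc3ccc(Cl)cc3)[nH]2)cc1`: 2290 nM
compound 3 `O=C(O)c1ccccc1-c1ccc(CCc2ncc(-c3ccccc3)[nH]2)cc1`: 4950 nM

Among these three, compound 3 gives the highest number in this assay: its nearest neighbour is compound 2, with a 2.2-fold higher number from compound 2 to compound 3 (0.33 log units; beyond the scatter), and the furthest is compound 1, with a 13-fold higher number from compound 1 to compound 3 (1.12 log units; beyond the scatter). Compound 1, carrying cyclohexyl, also stands apart from compound 2 by a 6.1-fold higher number from compound 1 to compound 2 (0.79 log units; beyond the scatter).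

The next compound, compound 4 `O=C(O)c1ccccc1-c1ccc(CCc2ncc(Cc3cccc(Cl)c3)[nH]2)cc1`, differs from compound 3 in one place: 3-chlorobenzyl in place of phenyl on an aromatic carbon. For the measured compounds named here, the step that bears most directly on it is the one between compound 2 and compound 3, a 2.2-fold higher number from compound 2 to compound 3 (0.33 log units; beyond the scatter), since compound 2 carries 4-chlorobenzyl and compound 4 carries 3-chlorobenzyl on the same aromatic carbon of the shared core. Taken backwards, that step suggests that replacing phenyl with a chlorobenzyl group lowers the number in this assay by a modest amount. Going by the values given here, no measured pair shows what moving the chlorine from the 4- to the 3-position does, so that part of the change is open.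

Compound 4 is therefore expected to give a modestly lower number than compound 3, a step estimated as a 2.3-fold lower number from compound 3 to compound 4 (0.35 log units; beyond the scatter). The estimate for compound 4 in this assay is 2200 nM, with a likely range of 700 nM to 6500 nM.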

Compound 4, half-maximal effective concentration: 825 nM
Beside the measured number, compound 4's estimate is 2.7-fold (0.43 log units) above it; measured number inside the range.
By their numbers in this assay, from the lowest: compound 1; then compound 4; then compound 2; then compound 3.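

In this assay, for the compounds shown here, the place of the chlorine on the benzyl group proves to matter at this aromatic carbon of the five-membered ring: 3-chlorobenzyl in place of 4-chlorobenzyl gives a 2.8-fold lower number from compound 2 to compound 4 (0.44 log units; beyond the scatter) in the first measured pair on that point. Set against phenyl, 3-chlorobenzyl gives a 6.0-fold lower number from compound 3 to compound 4 (0.78 log units; beyond the scatter) at the same carbon, so the two chlorobenzyl groups do not stand equally far from phenyl. Cyclohexyl still keeps its lead among the groups shown, since 3-chlorobenzyl in place of cyclohexyl gives a 2.2-fold higher number from compound 1 to compound 4 (0.34 log units; beyond the scatter) and leaves compound 1 with the lowest number of the four.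

Nothing available explains why moving the chlorine changes the number in this way.

The compounds shown also leave open how an unsubstituted benzyl group or a cyclohexylmethyl group would read at this carbon, and so whether the chlorine or the added chain carbon accounts for the change from phenyl, since both enter together in compound 4.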